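A few compounds are considered here, and "the series" means these few. Any claim that something is new, unique, unknown or untested is made for them only; others in the source may bear on it.

Compound 1 `C#CCN1CCCC(COC(=O)N(C)CC)C1`: > 100000 nM
Compound 2 `CCN(C)C(=O)OCC1CCCN(Cc2ccccc2)C1`: > 100000 nM

In an assay on BTI-TN-5B1-4 cells for inhibition of Amine oxidase [flavin-containing] B (Homo sapiens), read by fluorescence and Amplex Red, using microsomes, with a stated time of 15 min (a higher number here means a weaker inhibitor, a lower number a stronger inhibitor), compound 1 gives > 100000 nM, a limit of the assay and not a number. Compound 2 gives > 100000 nM in this assay, likewise a limit. Among the compounds with values here, the only measured step, a step that the two limits leave unreadable from compound 1 to compound 2, is therefore unreadable in size. Compound 2 stands at the limit of > 100000 nM in this assay, at which 2 of the 2 values shown sit; no number for it is known.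

Compound 3 `OCC1CCCN(Cc2ccccc2)C1` differs from compound 2 by hydrogen in place of ethyl(methyl)carbamoyl on an oxygen on a saturated carbon. Within the data shown here, no measured step touches this oxygen, and the one step measured is unreadable, so no size or direction is predicted from the data. Compound 3 is expected to give 100000 nM (range 20000 nM to 500000 nM), an estimated step of a number no higher from compound 2 to compound 3 (the limit leaves the size open) from compound 2.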

Compound 3, half-maximal inhibitory concentration: > 100000 nM
Compound 3: a limit, no number; the forecaster's own chance of this, stated with the estimate: 85%; the middle value sits exactly at the limit.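

Compound 3 gives > 100000 nM, a limit and not a number, so no step can be read between compound 2 and compound 3. The compounds shown leave open which change, if any, would give a measurable value.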